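Working notes on amine methyl removal in a fused amino-alcohol series

A few compounds are considered here, and "the series" means these few. Any claim that something is new, unique, unknown or untested is made for them only; others in the source may bear on it.

Measured so far:
- compound 1, `CN1CC[C@@H]2CC[C@H](O)C[C@@H]21`: > 300000 nM
- compound 2, `O[C@H]1CC[C@H]2CCN[C@H]2C1`: > 100000 nM
- compound 3, `CN1CCC2=CC[C@H](O)C[C@@H]21`: > 100000 nM

All three were run in an assay on HEK293 cells for antagonist activity at Nicotinic acetylcholine receptor alpha-4/beta-2 (Mus musculus), read by FLIPR, using a membrane potential dye; a higher number here means a weaker inhibitor, a lower number a stronger inhibitor. Compound 1 gives only a limit of the assay, > 300000 nM. Compound 2 likewise gives only a limit, > 100000 nM. Compound 3 too gives only a limit, > 100000 nM. The change hydrogen in place of methyl on an amine nitrogen in a ring gives a step that the two limits leave unreadable from compound 1 to compound 2; with both ends at a limit its size cannot be read. The cores of compound 1 and compound 3 differ in more than one place, and that difference is not broken down here. Two of the three values sit at the limit of > 100000 nM in this assay, at which 2 of the 3 values shown sit, and one at the limit of > 300000 nM in this assay, at which 1 of the 3 values shown sits.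

Compound 4, `O[C@H]1CC=C2CCN[C@H]2C1`, is not yet measured. It differs from compound 3 by hydrogen in place of methyl on an amine nitrogen in a ring. This is the same kind of change as that from compound 1 to compound 2, though not the same: in the earlier pair the place is also two ring bonds from the ring atom that bears a fused ring.

The expected step is a step that the limit leaves unreadable from compound 3 to compound 4. That rests on compound 3, which gives > 100000 nM, and on the earlier step that the two limits leave unreadable from compound 1 to compound 2, which left both ends at a limit. Compound 4 is therefore estimated at 200000 nM, with a range from 50000 nM to 1000000 nM, and is most likely to be reported again only as a limit.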

Compound 4, half-maximal inhibitory concentration: > 300000 nM
Compound 4: only a limit was reported; the forecaster's own chance of this, stated with the estimate: 90%; at least 1.5-fold (0.17 log units) between middle value and limit.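

With compound 3 and compound 4 both reported only as limits in this assay, no step can be read between them for hydrogen in place of methyl on the amine nitrogen. Since all four compounds shown give only limits, they leave open how strongly any of them inhibits, and whether removing the methyl changes that inhibition in either pair.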